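The source may hold more compounds than are shown below. What is called first, only, known or untested is meant among the compounds shown, and "the series" means these compounds.

Compound 2 `COc1ccc(C(=O)/C=C/c2cc(-c3cc(OC)c(OC)c(OC)c3)n[nH]2)cc1` and compound 1 `COc1cc(-c2cc(/C=C/C(=O)c3ccc(Cl)c(Cl)c3)[nH]n2)cc(OC)c1OC` share one core and differ only in the ring attached to the carbonyl carbon. In a functional assay on Malme-3M cells (Homo sapiens) for cytotoxicity, read by sulforhodamine B assay, with a stated time of 48 h, tested at 100 uM (on this read-out higher numbers stand for a weaker effect at the one concentration tested and lower numbers for a stronger effect), compound 1 gives 24%, while compound 2 gives -2%. For the measured compounds named here, compound 2 therefore stands at the lower of the two numbers, with compound 1 the only comparison: the step of a number 26 percentage points lower from compound 1 to compound 2 (beyond the scatter) is beyond the scatter and is modest in size.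

Compound 3 `COc1cc(-c2cc(/C=C/C(=O)c3ccc(F)c(F)c3)[nH]n2)cc(OC)c1OC` keeps the core of compound 2 but carries a different ring on the carbonyl carbon: 3,4-difluorophenyl in place of 4-methoxyphenyl on a carbonyl carbon. Going by the values given here, the one measured step that bears on this change is the one from compound 1 to compound 2, where a dihalogenated ring gave the higher number. The new ring of compound 3 is likewise a dihalogenated ring, so a return upward is expected, though not necessarily of full size. For compound 3 in this assay the expected step is a number 17 percentage points higher from compound 2 to compound 3 (beyond the scatter), giving an estimate of 15%, between -2% and 35%.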

Compound 3, a percentage reported as activity, at one concentration (the size of the read-out at that concentration, not a potency): -31%
Beside the measured number, compound 3's estimate is 46 percentage points above it; measured number outside the range, below it.
By their numbers in this assay, from the lowest: compound 3; then compound 2; then compound 1.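

Changing the halogens on the same ring has a large effect: with 3,4-difluorophenyl in place of 3,4-dichlorophenyl on a carbonyl carbon, this assay shows a number 55 percentage points lower from compound 1 to compound 3 (beyond the scatter) while the rest of the molecule stays the same. The 3,4-difluorophenyl ring also goes past 4-methoxyphenyl, with a number 29 percentage points lower from compound 2 to compound 3 (beyond the scatter) in the opposite direction to what the first pair suggested, so the two dihalogenated rings fall on either side of 4-methoxyphenyl and having two halogens does not by itself set the number at this position. No measurement here explains why these rings differ.

Still open, as far as these compounds go, is where a phenyl ring carrying a single fluorine, an amine or a carboxylic acid would fall at this position. A single concentration also leaves unknown how strong or weak the effect of these compounds would be at any other concentration.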